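The compounds below may be only part of what the source reports. "The series", "measured", "known", "first", "only" and "open" are said of these compounds alone.

Measured compounds in an ADME assay on HaCaT cells (Homo sapiens) for inhibition, read by sulforhodamine B assay, with a stated time of 48 h; a lower number here means a stronger inhibitor of growth, a higher number a weaker inhibitor of growth:
Compound 1 `Fc1ccc(Cn2cc(CCCOc3cccc4cccnc34)nn2)cc1` gives 115 ug/mL.
Compound 2 `Clc1ccc(Cn2cc(CCCOc3cccc4cccnc34)nn2)cc1` gives 4.2 ug/mL.
Compound 3 `Clc1cc(Cl)c(Cn2cc(CCCOc3cccc4cccnc34)nn2)c(Cl)c1` gives 5.3 ug/mL.

Compound 3 stands second highest of the three numbers; its nearest neighbour is compound 2, a 1.3-fold higher number from compound 2 to compound 3 (0.10 log units; within the scatter), and its furthest is compound 1, a 22-fold lower number from compound 1 to compound 3 (1.34 log units; beyond the scatter).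

Compound 4 `c1ccc(Cn2cc(CCCOc3cccc4cccnc34)nn2)cc1` differs from compound 3 by phenyl in place of 2,4,6-trichlorophenyl on a saturated chain carbon bound to an aromatic nitrogen. Going by the values given here, two measured steps bear on it. The change a 1.3-fold higher number from compound 2 to compound 3 (0.10 log units; within the scatter) shows that adding two chloro groups to a chlorinated phenyl changed little. The change a 27-fold lower number from compound 1 to compound 2 (1.44 log units; beyond the scatter) shows that the identity of a single halogen on the phenyl mattered greatly. Among the compounds with values here, no measured step removes every halogen from this phenyl, so the direction rests on compound 1 lying far from compounds 2 and 3.

For compound 4 the expected number is 30 ug/mL, range 8 ug/mL to 120 ug/mL. This estimate means a step of a 5.7-fold higher number from compound 3 to compound 4 (0.75 log units; beyond the scatter), expected toward a higher number but uncertain in size.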

Compound 4, concentration for 50% growth inhibition: 12.7 ug/mL
The estimate for compound 4 lay 2.4-fold (0.37 log units) above the measured number, within the range that was stated.
By their numbers in this assay, from the lowest: compounds 2 and 3 (each within the scatter of the next); then compound 4; then compound 1.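

In this assay the unsubstituted phenyl stands apart from both chlorinated compounds, with a 3.0-fold higher number from compound 2 to compound 4 (0.48 log units; beyond the scatter) and a 2.4-fold higher number from compound 3 to compound 4 (0.38 log units; beyond the scatter) when chlorine is lost. Halogen on this phenyl therefore does not act in one direction: chloro gives the lower numbers, while fluoro goes the other way, with a 9.1-fold lower number from compound 1 to compound 4 (0.96 log units; beyond the scatter) once it is removed. Nothing measured here accounts for this split between chloro and fluoro.

Open, going by these compounds, is whether a bromo or a methoxy group on this phenyl would side with chloro or with fluoro.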